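The source may hold more compounds than are shown below. What is called first, only, known or untested is meant among the compounds shown, and "the series" means these compounds.

Compound 1 `Cc1cc(C(=O)Nc2cc(C(F)(F)F)cc(C(F)(F)F)c2)nc(Cl)n1` was tested in an assay on Jurkat cells for activation of nuclear factor NF-kappa-B complex (Homo sapiens); on this read-out lower numbers stand for stronger inhibition and higher numbers for weaker inhibition. In this assay compound 1 gives only a limit, > 10000 nM. Compound 2 `O=C(Nc1cc(C(F)(F)F)cc(C(F)(F)F)c1)c1ccc(Cl)cc1C(F)(F)F` also returns a limit in this assay, > 30000 nM. Compound 3 `Cc1ncc(C(=O)Nc2cc(C(F)(F)F)cc(C(F)(F)F)c2)c(C(F)(F)F)n1` returns a limit in this assay as well, > 10000 nM; > 10000 nM (2 entries). Compound 1 therefore stands among three compounds of which none yields a number; all values shown are limits, the limit of > 10000 nM in this assay, at which 1 of the 3 values shown sits, and (the limit of > 30000 nM in this assay, at which 1 of the 3 values shown sits). Compound 4 `O=C(Nc1cc(C(F)(F)F)cc(C(F)(F)F)c1)c1cc(Cl)nc(Cl)n1` differs from compound 1 by a single change, (chloro in place of methyl on an aromatic carbon), in words chloro in place of methyl on an aromatic carbon. Among the compounds with values here, no measured pair shows this change, so the expected step that the limit leaves unreadable from compound 1 to compound 4 is none beyond the scatter. Compound 4 is estimated at 20000 nM, with a range from 5000 nM to 100000 nM, most probably again as a limit.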

Compound 4, half-maximal inhibitory concentration: > 10000 nM
Compound 4 ended at the assay's limit; the forecaster's own chance of this, stated with the estimate: 85%; the middle value does not contradict the limit.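

Compound 1 and compound 4 both end at a limit, so the step between them cannot be read: the limit of > 10000 nM in this assay, at which 2 of the 4 values shown sit.

The compounds shown leave open whether chloro in place of methyl on an aromatic carbon changes inhibition at all, since none of them yields a number.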